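A few compounds are considered here, and "the series" means these few. Any claim that something is new, unique, unknown or untested is made for them only; others in the source may bear on it.

Compound 1, `OC[C@H]1O[C@@H](n2cnc3c(NCc4ccc(Br)cc4)ncnc32)[C@H](O)[C@@H]1O`: in a functional assay on MCF cells (Homo sapiens) for antiproliferative activity, with a stated time of 72 h (a lower number here means a stronger inhibitor, a higher number a weaker inhibitor), compound 1 gives > 166000 nM, which is a limit of the assay.
Compound 2, `Cc1ccc(CNc2ncnc3c2ncn3[C@@H]2O[C@H](CO)[C@@H](O)[C@H]2O)cc1`: in this assay compound 2 gives > 166000 nM, again a limit.
Compound 3, `COc1ccccc1CNc1ncnc2c1ncn2[C@@H]1O[C@H](CO)[C@@H](O)[C@H]1O`: in this assay compound 3 gives > 166000 nM, also a limit.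

Compound 3 thus stands where every measured compound stands, at the limit (the limit of > 166000 nM in this assay, at which 3 of the 3 values shown sit), with no readable number anywhere. Compound 4, `OC[C@H]1O[C@@H](n2cnc3c(NCc4ccc(F)c(Cl)c4)ncnc32)[C@H](O)[C@@H]1O`, differs from compound 3 in one group only: 3-chloro-4-fluorophenyl in place of 2-methoxyphenyl on a saturated chain carbon bound to a nitrogen on an aromatic ring. The measured steps at this position, a step that the two limits leave unreadable from compound 1 to compound 3 and a step that the two limits leave unreadable from compound 2 to compound 3, and the step that the two limits leave unreadable from compound 1 to compound 2, all run between limits and give neither size nor direction. The step that the limit leaves unreadable from compound 3 to compound 4 is therefore expected to be unreadable as well. Compound 4 is estimated at 250000 nM, within a range of 60000 nM to 1000000 nM, most probably reported as a limit once more.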

Compound 4, half-maximal inhibitory concentration: > 166000 nM
Compound 4: no number, only a limit; the forecaster's own chance of this, stated with the estimate: 85%; the middle value does not contradict the limit.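

Compound 4, like compounds 1, 2 and 3, gives only a limit, so no step among these compounds can be read: the limit of > 166000 nM in this assay, at which 4 of the 4 values shown sit.

The compounds shown leave open whether any group at this place on the shared core gives a readable value in this assay.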